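A few compounds are considered here, and "the series" means these few. Any claim that something is new, unique, unknown or untested is made for them only; others in the source may bear on it.

Compound 1 `COc1ccc(C(=O)c2ccc(OC)c3c2OC(C)(C)C=C3)c(NC(=O)CO)c1`: 100 nM
Compound 2 `COc1ccc(C(=O)c2ccc(OC)c3c2OC(C)(C)C=C3)c(NC(=O)CN)c1`: 380 nM

Both values come from a functional assay on A2780 cells (Homo sapiens) for antiproliferative activity, read by MTT assay, with a stated time of 48 h; on this read-out lower numbers stand for stronger inhibition and higher numbers for weaker inhibition. Compound 2 has the higher of the two numbers, so it is the weaker inhibitor of this pair. The next compound for this read-out is compound 3 `CNCC(=O)Nc1cc(OC)ccc1C(=O)c1ccc(OC)c2c1OC(C)(C)C=C2`, which has methyl in place of hydrogen on an amine nitrogen.

Within the data shown here, only one measured step bears on this change. The step of a 3.8-fold higher number from compound 1 to compound 2 (0.58 log units; beyond the scatter) is modest and puts amino in place of hydroxy on a saturated chain carbon bound to a carbonyl carbon. It shows that the series responds to a change in this chain, but it does not test substitution on the amine nitrogen. Among the measured compounds shown here, no measured compound carries methyl there, so the size of the new step has no direct precedent, and the range has to stay wide. No step beyond the scatter is expected in this assay, and no direction is favoured. The estimate amounts to a 1.1-fold higher number from compound 2 to compound 3 (0.02 log units; within the scatter), which is an expected step within the scatter. For compound 3 the estimated value is 400 nM, with an expected range of 150 nM to 1000 nM.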

Compound 3, half-maximal inhibitory concentration: 620 nM
The estimate for compound 3 lay 1.6-fold (0.19 log units) below the measured number; the range from low to high includes it.
By their numbers in this assay, from the lowest: compound 1; then compounds 2 and 3 (each within the scatter of the next).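

In this assay methyl in place of hydrogen on the amine nitrogen gives a 1.6-fold higher number from compound 2 to compound 3 (0.21 log units; within the scatter) and so cannot be told apart from the usual scatter: this nitrogen, on a saturated chain carbon, carries the added methyl with no readable effect on the number. Among these compounds, the comparison with the hydroxy of compound 1 gives a 6.2-fold higher number from compound 1 to compound 3 (0.79 log units; beyond the scatter) and, unlike the single step to compound 2, shows that the gap from compound 1 is also beyond the scatter for the methylamino group, so that compound 1 stands apart from compounds 2 and 3 while these two read as one level. The data shown include no measurement that explains either step.

As far as these compounds go, whether dimethylamino, or a larger group such as ethylamino or a cyclic amine such as morpholine, would stay at the level of compounds 2 and 3 or come closer to compound 1 remains open. Also open, from the compounds shown here alone, is how a carboxylic acid in place of the amine, or a longer chain carrying the amino group, would read in this assay.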